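Cytotoxicity notes: from compound 1 toward compound 3

The source may hold more compounds than are shown below. What is called first, only, known or untested is meant among the compounds shown, and "the series" means these compounds.

Measured so far:
compound 1 `FC(F)(F)c1ccc(-c2ccc3c(NCCCNCc4ccco4)ccnc3c2)cc1`: 3470 nM
compound 2 `COc1cccc(CNCCCNc2ccnc3cc(-c4ccc(C(F)(F)F)cc4)ccc23)c1O`: 2210 nM

In an ADME assay on HepG2 cells (Homo sapiens) for cytotoxicity, read by luminescence, CellTiter-Glo and ATP content, with a stated time of 72 h (a higher number here means that more compound is needed for the effect, a lower number that less compound is needed), compound 1 gives 3470 nM, the highest of the two numbers, although the gap to compound 2 is small: a 1.6-fold lower number from compound 1 to compound 2 (0.20 log units; within the scatter). Compound 3 `c1coc(CNCCCNc2ccnc3cc(-c4cccc5ccccc45)ccc23)c1` differs from compound 1 by naphthalen-1-yl in place of 4-(trifluoromethyl)phenyl on an aromatic carbon. For the measured compounds named here, the single measured step concerns the group on a saturated chain carbon bound to an amine nitrogen, not the aromatic carbon changed here, so nothing measured bears on this change. For compound 3 no shift beyond the scatter is expected in this assay, an expected step of a 1.0-fold higher number from compound 1 to compound 3 (0.00 log units; within the scatter). Compound 3 is estimated at 3500 nM, range 1200 nM to 10000 nM.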

Compound 3, half-maximal effective concentration: 5600 nM
The estimate for compound 3 lay 1.6-fold (0.20 log units) below the measured number; the range from low to high includes it.
By their numbers in this assay, from the lowest: compounds 2, 1 and 3 (each within the scatter of the next, the first and the last beyond it).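

At the aromatic carbon of the shared core, naphthalen-1-yl in place of 4-(trifluoromethyl)phenyl gives a 1.6-fold higher number from compound 1 to compound 3 (0.21 log units; within the scatter) in this assay with the furan-2-yl chain end held constant. With 10 heavy atoms on each side of the swap, a second six-membered aromatic ring and three fluorine atoms are thus not told apart at this position in this pair. Nothing available explains this result.
Open, going by these compounds, is whether a carboxylic acid or a morpholine at this aromatic carbon would step beyond the scatter. Also open, on these data alone, is whether naphthalen-1-yl gives the same reading with the 2-hydroxy-3-methoxyphenyl group of compound 2 at the chain end.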